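Replacing a basic side chain by phenoxy on the benzylamine

The compounds below may be only part of what the source reports. "The series", "measured", "known", "first", "only" and "open" are said of these compounds alone.

Measured compounds:
- compound 1, `O=C(O)C1CC1c1ccc(NCc2ccc(-c3ccccc3)cc2)cc1`: 39.8 nM
- compound 2, `O=C(O)CCc1ccc(NCc2ccccc2Cl)cc1`: 3980 nM
- compound 3, `CN(C)Cc1ccc(CNc2ccc(CCC(=O)O)cc2)cc1`: < 31700 nM

All three compounds share an aminophenyl acid core, and all were tested in a functional assay for agonist activity at Free fatty acid receptor 1 (Homo sapiens); a higher number here means that more compound is needed for the effect, a lower number that less compound is needed. Compound 1 gives 39.8 nM and compound 2 gives 3980 nM in this assay. For compound 3, this assay reports only a limit, < 31700 nM, and not a number, so its actual potency is not pinned down. No two of these compounds differ in just one place, so no single measured step can be read off; the two values of compound 1 and compound 2 simply show that the series spans a wide range of potencies.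

Compound 4, `O=C(O)CCc1ccc(NCc2ccc(Oc3ccccc3)cc2)cc1`, has not yet been measured. It differs from compound 3 by one change: phenoxy in place of (dimethylamino)methyl on an aromatic carbon. The chain that leaves carries a basic nitrogen; the group that enters is a second aromatic ring joined through oxygen, on an aromatic carbon para to a large group. For the measured compounds named here, since compound 3 is known only as a limit, no measured step in this assay anchors the comparison, and the expectation rests on the values of compound 1 and compound 2. Compound 4 is expected to be considerably more potent, with an estimated step from compound 3 of a step that the limit leaves unreadable from compound 3 to compound 4. The estimate for compound 4 in this assay is 100 nM, with a range from 25 nM to 400 nM.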

Compound 4, half-maximal effective concentration: 195 nM
Compound 4: the middle estimate sits 2.0-fold (0.29 log units) below what was measured, and the stated range covers the measured number.
By their numbers in this assay, from the lowest: compound 1; then compound 4; then compound 2.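

The change from compound 3 to compound 4 cannot be given a size in this assay, because the result for compound 3 is a limit and not a number: the limit of < 31700 nM in this assay, at which 1 of the 4 values shown sits.

The compounds shown leave open how much potency is gained or lost when phenoxy takes the place of (dimethylamino)methyl.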